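The compounds below may be only part of what the source reports. "The series", "measured", "known", "first", "only" and "open" are said of these compounds alone.

Compound 3 `CN1CCN(C(=O)/C=C/c2ccncc2-c2ccc3ccccc3c2)CC1` stands at a limit in a functional assay on A549 cells (Homo sapiens) for inhibition, read by sulforhodamine B assay, with a stated time of 72 h; on this read-out higher numbers stand for weaker inhibition of growth and lower numbers for stronger inhibition of growth: compound 3 gives > 10000 nM, which is a limit of the assay rather than a number. Compound 1 `NC(=O)/C=C/c1ccncc1-c1ccc2ccccc2c1` likewise reaches only a limit, giving > 10000 nM. Compound 2 `COC(=O)/C=C/c1ccncc1-c1ccc2ccccc2c1` gives a number in this assay, namely 760 nM. The step of an at least 13-fold higher number from compound 2 to compound 3 (1.11 log units; beyond the scatter) is large, whereas a step that the two limits leave unreadable from compound 1 to compound 3 cannot be read because of the limit of > 10000 nM in this assay, at which 2 of the 3 values shown sit. Compound 4 `O=C(/C=C/c1ccncc1-c1ccc2ccccc2c1)N1CCOCC1` differs from compound 3 by morpholin-4-yl in place of 4-methylpiperazin-1-yl on a carbonyl carbon. Since the two amine-substituted carbonyl compounds, compound 1 and compound 3, both sit at the limit, no step beyond the scatter is expected, and the estimated step is a step that the limit leaves unreadable from compound 3 to compound 4. Compound 4 is therefore expected to give about 15000 nM, between 4000 nM and 50000 nM, most probably again only as a limit.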

Compound 4, concentration for 50% growth inhibition: 8410 nM
Compound 4: middle estimate off by 1.8-fold (0.25 log units), on the high side, and the stated range covers the measured number.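

With morpholin-4-yl on the carbonyl carbon, this assay gives a number rather than a limit for an amide in this set, so the distance from the methoxy compound can now be measured: an 11-fold higher number from compound 2 to compound 4 (1.04 log units; beyond the scatter). The steps of an at least 1.1-fold lower number from compound 3 to compound 4 (0.07 log units; that floor lies within the scatter) and an at least 1.1-fold lower number from compound 1 to compound 4 (0.07 log units; that floor lies within the scatter) do not separate morpholin-4-yl from 4-methylpiperazin-1-yl or amino. Both steps start from a value that is only a limit: the limit of > 10000 nM in this assay, at which 2 of the 4 values shown sit.

As far as these compounds go, it remains open whether an ethoxy ester or a carboxylic acid would stay close to compound 2 or fall with the amides. From the compounds shown here alone, a piperidin-1-yl amide is equally open.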